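The compounds below may be only part of what the source reports. "The series", "measured", "known", "first", "only" and "open" are said of these compounds alone.

Measured so far:
compound 1 `COc1cccc(CNc2ncnc3c2ncn3C2CCCCO2)c1` with 97000 nM
compound 2 `COc1ccc(OC)c(CNc2ncnc3c2ncn3C2CCCCO2)c1` with 25400 nM
compound 3 `COc1cccc(OC)c1CNc1ncnc2c1ncn2C1CCCCO1` with > 100000 nM

These three compounds were tested in an ADME assay on MCF7 cells (Homo sapiens) for cytotoxicity, with a stated time of 72 h; on this read-out higher numbers stand for weaker inhibition and lower numbers for stronger inhibition. Compound 1 gives 97000 nM. Compound 2 gives 25400 nM. Compound 3 reaches only the limit of the assay, so for compound 3 the figure > 100000 nM is a limit and not a number, as the evidence the limit of > 100000 nM in this assay, at which 1 of the 3 values shown sits, records.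

Compound 1 and compound 2 differ in one place, (methoxy in place of hydrogen on an aromatic carbon), and in this assay the step of a 3.8-fold lower number from compound 1 to compound 2 (0.58 log units; beyond the scatter). The difference between the core of compound 1 and the core of compound 3 is not broken down here.

The unmeasured compound 4 `COc1cc(OC)c(CNc2ncnc3c2ncn3C2CCCCO2)c(OC)c1` arises from compound 3 by the same kind of change, (methoxy in place of hydrogen on an aromatic carbon). The surroundings of the place differ: in compound 2 the entering group sits ortho to a large group and para to a methoxy group, while in compound 4 it sits meta to two methoxy groups and para to a large group. Going by the values given here, since compound 3 sits at a limit, there is no number to build the step on; the step from compound 1 to compound 2 is the only guide, and a weaker read-out than that of compound 2 is expected. For compound 4 the estimated step of an at least 1.2-fold lower number from compound 3 to compound 4 (0.09 log units; that floor lies within the scatter) is expected, so compound 4 is estimated at 80000 nM, with the range 25000 nM to 300000 nM.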

Compound 4, half-maximal inhibitory concentration: > 50000 nM
Compound 4 ended at the assay's limit; the forecaster's own chance of this, stated with the estimate: 45%; the middle value does not contradict the limit.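

In this assay compound 3 stands at a limit, > 100000 nM. Going by these compounds alone, compound 4 also stands at a limit, > 50000 nM, and with two limits no step from compound 3 to compound 4 can be read. The compounds shown leave open whether methoxy in place of hydrogen, at this place meta to two methoxy groups, changes the read-out at all.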